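The source may report more compounds than this note shows. Statements on the series, on what has been measured and on what is new or still open speak of the compounds shown alone.

The measured compounds:
Compound 1 `C#Cc1cn([C@@H]2O[C@H](CO)[C@@H](O)[C@H]2O)c2ncnc(N(C)C)c12` gives 290 nM in a functional assay on HL-60 cells (Homo sapiens) for antiproliferative activity, read by XTT assay, with a stated time of 72 h; on this read-out higher numbers stand for weaker inhibition and lower numbers for stronger inhibition.
Compound 2 `CNc1ncnc2c1c(-c1cccs1)cn2[C@@H]1O[C@H](CO)[C@@H](O)[C@H]1O` gives > 20000 nM in this assay, which is a limit of the assay and not a number.
Compound 3 `CSc1ncnc2c1c(-c1cccs1)cn2[C@@H]1O[C@H](CO)[C@@H](O)[C@H]1O` gives 1130 nM in this assay.

Among the two numbers shown, compound 3 has the higher one; its nearest neighbour is compound 1, whose number is lower by a gap beyond the scatter. Compound 4 `CN(C)c1ncnc2c1c(-c1cccs1)cn2[C@@H]1O[C@H](CO)[C@@H](O)[C@H]1O` differs from compound 3 in one place: dimethylamino in place of methylsulfanyl on an aromatic carbon. For the measured compounds named here, the only measured step at that position is an at least 17-fold lower number from compound 2 to compound 3 (1.24 log units; beyond the scatter). Its size is known only as a bound because compound 2 sits at the limit of > 20000 nM in this assay, at which 1 of the 3 values shown sits. Compound 1 carries the dimethylamino group that enters in compound 4, but it also differs from compound 3 elsewhere, so its value shows only that dimethylamino can sit at this position in an active compound. Since methylamino gave no measurable inhibition and methylsulfanyl gave a moderate number, the dimethylamino group is expected to land near compound 3, with the larger risk on the weaker side, so that the step of a 1.3-fold higher number from compound 3 to compound 4 (0.12 log units; within the scatter) is expected to stay within or just beyond the scatter. Compound 4 is therefore estimated at 1500 nM in this assay, with a range from 300 nM to 8000 nM.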

Compound 4, half-maximal inhibitory concentration: 11800 nM
The estimate for compound 4 lay 7.9-fold (0.90 log units) below the measured number; measured number above the stated range.
By their numbers in this assay, from the lowest: compound 1; then compound 3; then compound 4. At a limit, above all of these: compound 2.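

With thiophen-2-yl held fixed in this assay, dimethylamino in place of methylsulfanyl gives a 10-fold higher number from compound 3 to compound 4 (1.02 log units; beyond the scatter), so methylsulfanyl is clearly favoured over dimethylamino at this position on the shared core. Methyl in place of hydrogen on the nitrogen gives an at least 1.6-fold lower number from compound 2 to compound 4 (0.22 log units; that floor lies within the scatter), and this step is only a bound with no firm gain from the added methyl, because compound 2 sits at a limit of the assay and not at a number: the limit of > 20000 nM in this assay, at which 1 of the 4 values shown sits. With dimethylamino held fixed, thiophen-2-yl in place of ethynyl gives a 41-fold higher number from compound 1 to compound 4 (1.61 log units; beyond the scatter), so the activity of compound 1 does not carry over to the thiophen-2-yl series, and dimethylamino alone does not secure it.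

On these data alone, whether methylsulfanyl would also be favoured over dimethylamino with ethynyl on the core stays open. Equally open is where a plain amino group, a methoxy group or a longer chain such as ethylsulfanyl would fall at this position, so the compounds shown do not say how far the preference for methylsulfanyl extends.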